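Mouse microsomal stability across the fused-core series

The compounds below may be only part of what the source reports. "The series", "measured", "known", "first", "only" and "open" are said of these compounds alone.

Measured so far:
compound 1 `C[C@H](Nc1ccnc(N)n1)c1cc2ccc(F)cn2c(=O)c1-c1ccccc1` — "not determined" (no result reported)
compound 2 `Cc1cccc(-c2c([C@H](C)Nc3nc(N)nc(N)c3C#N)cc3ccc(F)cn3c2=O)c1` — < 1%
compound 3 `Cc1c([C@H](C)Nc2nc(N)nc(N)c2C#N)c(-c2ccccc2)c(=O)n2cc(F)ccc12` — 85%

For the measured compounds named here, in an ADME assay on microsomes from liver (Mus musculus), read by LC-MS, using NADPH, with a stated time of 30 min, tested at 1 uM (a lower number here means that less of the compound is left, a higher number that more of the compound is left), compound 3 gives 85%, the only plain number in the set. Compound 2 reaches only (the limit of < 1% in this assay, at which 1 of the 3 values shown sits), and that limit is not a number. Compound 1 carries no result in this assay. Going by the values given here, no step between two measured compounds can be drawn, so compound 3 stands alone as the reference.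

Compound 4 `COc1ccc(-c2c([C@H](C)Nc3nc(N)nc(N)c3C#N)c(-c3ccccc3)c(=O)n3cc(F)ccc23)cc1` differs from compound 3 by 4-methoxyphenyl in place of methyl on an aromatic carbon. Among the compounds with values here, with no measured step to lean on, the expected direction is a fall in the percent remaining, of moderate size and beyond the scatter, written as a number 30 percentage points lower from compound 3 to compound 4 (beyond the scatter). Compound 4 is estimated at 55%, within 20% to 85%.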

Compound 4, percent of the compound remaining: 82%
Estimate against measurement, compound 4: 27 percentage points below; low and high end bracket the measured number.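

In this assay, swapping 4-methoxyphenyl for methyl on this aromatic carbon gives a number 3 percentage points lower from compound 3 to compound 4 (within the scatter). For the compounds shown here, this is the first readable step, and it shows that this position takes a group of 8 heavy atoms with a six-membered aromatic ring and still reads the same as the methyl compound within the scatter. Nothing at hand bears on why the reading holds.

Going by these compounds alone, compound 2 stays at a limit, < 1%, which is not a number and gives no step. Open, on these data alone, is whether an amine or a carboxylic acid on this aromatic carbon would read the same way in this assay.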